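From aminocarbamoyl to morpholinylcarbonyl on a shared core

The compounds below may be only part of what the source reports. "The series", "measured", "known", "first", "only" and "open" are said of these compounds alone.

Measured so far:
compound 1, `NNC(=O)CCc1ccncc1-c1ccc2ccccc2c1`, 7.7 nM
compound 2, `O=C(O)COc1ccncc1-c1ccc2ccccc2c1`, "not determined" (no result reported)
compound 3, `O=C(O)/C=C/c1ccncc1-c1ccc2ccccc2c1`, 5 nM

These compounds share one core and differ in the group attached to an aromatic carbon. In an assay on a protein complex for inhibition of CDK8/Cyclin C (Homo sapiens), with a stated time of 1 h (on this read-out lower numbers stand for stronger inhibition and higher numbers for weaker inhibition), compound 1 gives 7.7 nM, the highest of the two numbers available, while compound 3 gives 5 nM; the step of a 1.5-fold lower number from compound 1 to compound 3 (0.19 log units; within the scatter) lies within the scatter. Compound 2 has no result in this assay. Compound 4, `O=C(CCc1ccncc1-c1ccc2ccccc2c1)N1CCOCC1`, is not yet measured and differs from compound 1 by morpholin-4-yl in place of aminoamino on a carbonyl carbon. Among the measured compounds shown here, no measured step alters the carbonyl substituent in this way, so the only guide is that the one measured change on this core, a 1.5-fold lower number from compound 1 to compound 3 (0.19 log units; within the scatter), moved little. Compound 4 is therefore expected to stay close to compound 1, with a step of a 1.9-fold higher number from compound 1 to compound 4 (0.29 log units; within the scatter) expected. The estimate for compound 4 is 15 nM, with a range from 4 nM to 60 nM.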

Compound 4, half-maximal inhibitory concentration: 45.5 nM
Estimate against measurement, compound 4: 3.0-fold (0.48 log units) below, within the range that was stated.
By their numbers in this assay, from the lowest: compounds 3 and 1 (each within the scatter of the next); then compound 4.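

Unlike the step of a 1.5-fold lower number from compound 1 to compound 3 (0.19 log units; within the scatter), which stays within the scatter, the change on the carbonyl carbon in this assay is one that can be read as real: morpholin-4-yl in place of aminoamino gives a 5.9-fold higher number from compound 1 to compound 4 (0.77 log units; beyond the scatter). The group on this carbonyl carbon therefore affects the read-out, and the larger ring-bearing group goes with the higher number in this one pair. Nothing measured here explains the change.

On these data alone, whether piperidin-1-yl or dimethylamino on the same carbonyl carbon would follow morpholin-4-yl remains open. So does the outcome for a carboxylic acid on the same saturated chain, or for a longer chain.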